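The source may report more compounds than this note shows. Statements on the series, on what has been measured and on what is new or still open speak of the compounds shown alone.

Compound 1 `N=C(NC(=N)NC1CCCC1)Nc1ccc(C(F)(F)F)cc1` gives 3700 nM in a functional assay on T-24 cells (Homo sapiens) for antiproliferative activity, read by MTT assay, with a stated time of 72 h (on this read-out higher numbers stand for weaker inhibition and lower numbers for stronger inhibition), and compound 2 `CCCCCCCNC(=N)NC(=N)Nc1ccc(F)c(F)c1` gives 4300 nM; the two numbers lie within the usual scatter of each other, so neither stands apart on the evidence in hand. Compound 3 `CC(C)CNC(=N)NC(=N)Nc1ccc(C(F)(F)F)cc1` has not yet been measured. It differs from compound 1 by isobutyl in place of cyclopentyl on an amine nitrogen. Within the data shown here, no pair of measured compounds shows a comparable change, so only an expectation can be offered: a step within the scatter, in no particular direction. The estimate for compound 3 in this assay is 4000 nM, with a range from 1500 nM to 11000 nM. The expected step is a 1.1-fold higher number from compound 1 to compound 3 (0.03 log units; within the scatter), staying within the scatter.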

Compound 3, half-maximal inhibitory concentration: 3100 nM
Estimate against measurement, compound 3: 1.3-fold (0.11 log units) above, within the range that was stated.
By their numbers in this assay, from the lowest: compounds 3, 1 and 2 (each within the scatter of the next).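

In this assay, isobutyl in place of cyclopentyl on this amine nitrogen gives a 1.2-fold lower number from compound 1 to compound 3 (0.08 log units; within the scatter). On this evidence, the open-chain group and the ring cannot be told apart at this position, at least for this pair of groups on the shared core. Nothing at hand bears on the reason for this result.

The compounds shown leave open whether a benzyl group, or a chain ending in a carboxylic acid, on this amine nitrogen would also stay within the scatter of compound 1. Compound 2 differs from compound 1 in more than one place, so it cannot settle what a longer chain does here.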